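The source may report more compounds than this note shows. Statements on the series, on what has been measured and on what is new or still open speak of the compounds shown alone.

Measured so far:
compound 1 `O=C(/C=C/c1ccc(Br)cc1)NNC(=O)c1ccc2c(c1)OCCO2` — 259000 nM
compound 2 `O=C(/C=C/c1cccc(Br)c1)NNC(=O)c1ccc2c(c1)OCCO2` — 351000 nM

In an ADME assay on cells (Macrophage) for cytotoxicity, read by MTT assay, with a stated time of 24 h (on this read-out lower numbers stand for higher toxicity in this test and higher numbers for lower toxicity in this test), compound 2 gives 351000 nM, the higher of the two numbers, though the gap to compound 1 is small. Compound 3 `O=C(/C=C/c1ccccc1Cl)NNC(=O)c1ccc2c(c1)OCCO2` has not been measured. The change from compound 2 to compound 3 is 2-chlorophenyl in place of 3-bromophenyl on a double-bonded chain carbon bound to a double-bonded chain carbon. Among the compounds with values here, the only measured step, a 1.4-fold higher number from compound 1 to compound 2 (0.13 log units; within the scatter), moved a bromine around the same ring and stayed within the scatter, so the new step is expected to be small as well: a 1.2-fold lower number from compound 2 to compound 3 (0.07 log units; within the scatter). Compound 3 is therefore estimated at 300000 nM, in a range from 120000 nM to 800000 nM.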

Compound 3, half-maximal cytotoxic concentration: 285000 nM
Compound 3: middle estimate off by 1.1-fold (0.02 log units), on the high side; low and high end bracket the measured number.
By their numbers in this assay, from the lowest: compounds 1, 3 and 2 (each within the scatter of the next).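

Replacing a bromophenyl group with 2-chlorophenyl on this chain carbon changes the halogen as well as its place on the ring, yet in this assay both steps stay within the scatter (a 1.2-fold lower number from compound 2 to compound 3 (0.09 log units; within the scatter); a 1.1-fold higher number from compound 1 to compound 3 (0.04 log units; within the scatter)). Within the data shown here, the 2-chlorophenyl, 3-bromophenyl and 4-bromophenyl groups therefore cannot be told apart in this test, whereas the earlier pair compared only two bromophenyl groups. No outside information bears on this result. Still open, as far as these compounds go, is whether an aminophenyl or carboxyphenyl group here would give a number beyond the scatter.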